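The source may hold more compounds than are shown below. What is called first, only, known or untested is meant among the compounds shown, and "the series" means these compounds.

Going by the values given here, in a functional assay on HT-29 cells (Homo sapiens) for cytotoxicity, read by MTT assay, with a stated time of 3 days (a higher number here means a weaker inhibitor, a lower number a stronger inhibitor), compound 1 `COc1cccc(-c2cccc(O)c2)c1` gives 16 ug/mL as the lowest of the three numbers so far. Compound 3 `Nc1ccc(-c2cccc(O)c2)cc1` at 49.3 ug/mL and compound 2 `Nc1cccc(-c2cccc(O)c2)c1` at 54 ug/mL both sit higher. Compound 4 `COc1ccc(-c2cccc(O)c2)cc1OC` has methoxy in place of hydrogen on an aromatic carbon, ortho to a methoxy group (methoxy in place of hydrogen on an aromatic carbon), and otherwise matches compound 1. Among the compounds with values here, the one measured step at a methoxy group is a 3.4-fold higher number from compound 1 to compound 2 (0.53 log units; beyond the scatter) when amino replaces methoxy. That modest step removes a methoxy rather than adding one, so it guides only loosely. In this assay the expected result is therefore a 1.1-fold lower number from compound 1 to compound 4 (0.06 log units; within the scatter) with no clear shift beyond the scatter. Compound 4 is estimated at 14 ug/mL with an expected range from 5 ug/mL to 40 ug/mL for this measurement.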

Compound 4, half-maximal inhibitory concentration: 29 ug/mL
Compound 4: middle estimate off by 2.1-fold (0.32 log units), on the low side, within the range that was stated.
By their numbers in this assay, from the lowest: compounds 1, 4, 3 and 2 (each within the scatter of the next, the first and the last beyond it).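

Placing a methoxy group on this aromatic carbon, ortho to a methoxy group, gives a 1.8-fold higher number from compound 1 to compound 4 (0.26 log units; within the scatter) in this assay, so the added group brings no shift that can be told from the scatter. Unlike the earlier step, which swaps one group for another, this one shows a group added to the core of compound 1 at a new place. Nothing available explains this result. The compounds shown leave open whether an amine, a fluorine or a longer chain such as ethoxy on this same carbon would also stay within the scatter.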